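Notes on the step from compound 3 to compound 4

The source may report more compounds than this note shows. Statements on the series, on what has been measured and on what is new or still open speak of the compounds shown alone.

Three compounds have numbers in a functional assay on the whole organism (strain CF-1) for inhibition, with Mus musculus as the target; a lower number here means that less compound is needed, a higher number that more compound is needed for the effect. Compound 1 `CN(C)CCn1nc(CN(C)C)n(-c2ccc(Cl)cc2C(=O)c2ccccc2)c1=O` gives 6.3 mg/kg. Compound 2 `Cc1nnc(CN2CCCC2)n1-c1ccc(Cl)cc1C(=O)c1ccccc1` gives 0.4 mg/kg. Compound 3 `CN(C)Cc1nnc(-c2ccncc2)n1-c1ccc(Cl)cc1C(=O)c1ccccc1Cl` gives 11 mg/kg, the highest of the three; it lies within the scatter of compound 1, while compound 2 stands well beyond the scatter at a lower number.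

Compound 4 `CN(C)Cc1nnc(C2CC2)n1-c1ccc(Cl)cc1C(=O)c1ccccc1Cl` is compound 3 with cyclopropyl in place of pyridin-4-yl on an aromatic carbon. Going by the values given here, no measured pair differs in one place, so no single step is known. A moderate move to a lower number is expected in this assay, a 2.8-fold lower number from compound 3 to compound 4 (0.44 log units; beyond the scatter), since compound 2, which bears a methyl rather than an aryl group, gives 0.4 mg/kg. Compound 4 is expected near 4 mg/kg, between 1.5 mg/kg and 12 mg/kg.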

Compound 4, dose for half-maximal effect: 0.6 mg/kg
Compound 4: the middle estimate sits 6.7-fold (0.82 log units) above what was measured, and the stated range ends above it.
By their numbers in this assay, from the lowest: compounds 2 and 4 (each within the scatter of the next); then compounds 1 and 3 (each within the scatter of the next).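

In this assay, going by these compounds alone, cyclopropyl in place of pyridin-4-yl on the aromatic carbon between two ring nitrogen atoms gives an 18-fold lower number from compound 3 to compound 4 (1.26 log units; beyond the scatter) as the first single-place step. Within the data shown here, this position therefore responds strongly to the group it bears, which the earlier compounds, differing in several places, could not show. Nothing at hand accounts for the size of this step.

Open, on these data alone, is whether the step follows from the ring nitrogen of pyridin-4-yl or from the whole aromatic ring. Phenyl at this position would separate the two, and isopropyl or ethyl would show how far the cyclopropyl ring itself matters.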